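A few compounds are considered here, and "the series" means these few. Any claim that something is new, unique, unknown or untested is made for them only; others in the source may bear on it.

Among the measured compounds shown here, compound 2 `COc1ccc(CS(=O)(=O)/C=C/c2c(OC)cccc2OC)cc1[N+](=O)[O-]` gives 10200 nM in a functional assay on HCT-116 cells (Homo sapiens) for cytotoxicity, read by MTT assay, with a stated time of 72 h (on this read-out lower numbers stand for stronger inhibition of growth and higher numbers for weaker inhibition of growth), the only numeric value in this set. Compound 1 `COc1cc(OC)c(/C=C/S(=O)(=O)Cc2ccc(OC)c(N)c2)c(OC)c1`, which also carries an amino group, sits at a limit of this assay rather than at a number, < 10 nM, as recorded in the limit of < 10 nM in this assay, at which 1 of the 2 values shown sits. Compound 3 `COc1ccc(CS(=O)(=O)/C=C/c2c(OC)cccc2OC)cc1N` is the analogue of compound 2 with amino in place of nitro on an aromatic carbon. For the measured compounds named here, no measured pair shows this exact change, so the expected size of the step in this assay rests only on the two values above. Compound 3 is expected to gain potency, with an estimated step of a 100-fold lower number from compound 2 to compound 3 (2.01 log units; beyond the scatter). Compound 3 is estimated at 100 nM, within 10 nM to 1000 nM.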

Compound 3, concentration for 50% growth inhibition: 20 nM
Estimate against measurement, compound 3: 5.0-fold (0.70 log units) above; low and high end bracket the measured number.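

The change to amino gives a 510-fold lower number from compound 2 to compound 3 (2.71 log units; beyond the scatter) in this assay and so shows that this place, ortho to a methoxy group, is far from indifferent to the group it carries. Hydrogen in place of methoxy on an aromatic carbon gives an at least 2.0-fold higher number from compound 1 to compound 3 (0.30 log units; that floor lies within the scatter) and so offers no sign that the further methoxy of compound 1 is needed for a low number. Compound 1 stands at a limit, so this comparison has only a floor: the limit of < 10 nM in this assay, at which 1 of the 3 values shown sits.

Going by these compounds, what a hydroxyl group, a methylamino group or an acetamide would give at this place stays open. So does whether amino would show a step of similar size on the core of compound 1.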